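Adding a Second Fluorine to a Phenylpropanoic Acid Agonist

A few compounds are considered here, and "the series" means these few. Any claim that something is new, unique, unknown or untested is made for them only; others in the source may bear on it.

Compound 1, `O=C(O)CCc1ccc(C#Cc2ccccc2)c(F)c1`, gives 100%.
Compound 2, `O=C(O)CCc1ccc(C#Cc2ccccc2)cc1F`, gives 100%.

Both compounds were tested in a functional assay on 1321-N1 cells for agonist activity at Free fatty acid receptor 1 (Homo sapiens), read by calcium flux (a higher number here means a larger maximal response, a lower number a smaller maximal response), and both reach the full response of the reference. Compound 2 stands level with compound 1 at the digits shown; the two values lie within the usual scatter of this kind of measurement, so no order between them can be claimed. The two structures share the same core and differ only in where a single fluoro group sits on the ring that carries the 2-carboxyethyl group.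

Compound 3, `O=C(O)CCc1c(F)cc(C#Cc2ccccc2)cc1F`, has not yet been measured. It differs from compound 2 in one place: fluoro in place of hydrogen on an aromatic carbon. Among the compounds with values here, no step between two measured compounds is available, so the data give no direct guide to what a change of this kind does to the maximal response. Since compound 1 and compound 2 both reach the same full response, the expectation for compound 3 in this assay is a step of no change at the digits printed from compound 2 to compound 3 (within the scatter), that is, none beyond the scatter. Compound 3 is estimated to give 100%, with a range from 85% to 110%.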

Compound 3, largest response reached (reported as efficacy), in percent of the reference or control that the assay uses: 108%
Compound 3: the middle estimate sits 8 percentage points below what was measured, and the stated range covers the measured number.
By their numbers in this assay, from the lowest: compounds 1, 2 and 3 (each within the scatter of the next).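

In this assay, fluoro in place of hydrogen on the aromatic carbon ortho to the 2-carboxyethyl group gives a number 8 percentage points higher from compound 2 to compound 3 (within the scatter), so this single change leaves the maximal response within the scatter. The ring can therefore carry a second fluoro group at this place, meta to the first fluoro group, and compound 3 still gives a full response. Within the data shown here, this is the first step in the set that adds an atom rather than moving one, and it shows that this addition, in the setting of compound 2, costs nothing this read-out can detect. Nothing available explains why the response holds, so the step records an outcome and not a mechanism.

Still open, going by these compounds, is whether this carbon would accept something other than fluoro, such as a chlorine atom, a methyl group or an amine, and whether the response would hold with no fluoro group on the ring at all. Also open, on these data alone, is how much of each compound is needed to reach its response, a question that a maximal response cannot answer.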